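A few compounds are considered here, and "the series" means these few. Any claim that something is new, unique, unknown or untested is made for them only; others in the source may bear on it.

Measured so far:
compound 1 `CCCCCCNc1cc(-c2ccccc2)c(-c2ccccc2)nn1` — 24000 nM
compound 2 `CCCCCCCSc1cc(-c2ccccc2)c(-c2ccccc2)nn1` — 76000 nM

In an assay on microsomes from liver for inhibition of sterol O-acyltransferase 1 (Rattus norvegicus) (a higher number here means a weaker inhibitor, a lower number a stronger inhibitor), compound 2 gives 76000 nM, the higher of the two numbers; compound 1 gives 24000 nM, and a 3.2-fold higher number from compound 1 to compound 2 (0.50 log units; beyond the scatter). Compound 3 `CCCCCCS(=O)(=O)c1cc(-c2ccccc2)c(-c2ccccc2)nn1` differs from compound 2 by hexylsulfonyl in place of heptylsulfanyl on an aromatic carbon. Among the compounds with values here, no measured step tests this kind of change: the one known step swaps one chain for another at the same place and gives no direct guide. With nothing to point either way, compound 3 is expected at 80000 nM, within a range from 20000 nM to 300000 nM, a step of a 1.1-fold higher number from compound 2 to compound 3 (0.02 log units; within the scatter).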

Compound 3, half-maximal inhibitory concentration: 60000 nM
For compound 3 the middle estimate is 1.3-fold (0.12 log units) above the measured one; the measured number falls inside the stated range.
By their numbers in this assay, from the lowest: compound 1; then compounds 3 and 2 (each within the scatter of the next).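

In this assay, hexylsulfonyl in place of heptylsulfanyl gives a 1.3-fold lower number from compound 2 to compound 3 (0.10 log units; within the scatter), so at this aromatic carbon these two sulfur-linked chains cannot be told apart. With the six-carbon chain kept, hexylsulfonyl in place of hexylamino gives a 2.5-fold higher number from compound 1 to compound 3 (0.40 log units; beyond the scatter), which leaves compound 1 with the lowest number of the three. Nothing at hand explains these numbers.

Still open, from the compounds shown here alone, is whether the amine link keeps its lead with a shorter or longer chain. An ether link or a carboxylic acid at this position also remains untested in the compounds shown.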